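Chloro for Methoxy on the Anilide Ring in the Paw-Edema Read-Out

The compounds below may be only part of what the source reports. "The series", "measured", "known", "first", "only" and "open" are said of these compounds alone.

Compound 1 `COc1ccc(NC(=O)c2c(O)c3cccnc3n(-c3ccccc3)c2=O)cc1`: -1.9%
Compound 2 `O=C(Nc1ccc(Cl)cc1)c1c(O)c2cccnc2n(-c2ccccc2)c1=O`: 2.5%
Compound 3 `COc1cccc(NC(=O)c2c(O)c3cccnc3n(-c3ccccc3)c2=O)c1`: 20.7%

In a functional assay on the whole organism for inhibition, with Rattus norvegicus as the target, read by cytopathic effect and paw edema, at a dose of 100 mg/kg by the oral route (on this read-out higher numbers stand for more inhibition at the one dose given (going by the name of the read-out) and lower numbers for less inhibition), compound 1 gives -1.9%, compound 2 gives 2.5% and compound 3 gives 20.7%. Compound 1 and compound 2 differ by chloro in place of methoxy on an aromatic carbon, a change that made a number 4.4 percentage points higher from compound 1 to compound 2 (within the scatter). The cores of compound 1 and compound 3 differ by 3-methoxyphenyl in place of 4-methoxyphenyl on an amide-type nitrogen, and that move gave a number 22.6 percentage points higher from compound 1 to compound 3 (beyond the scatter); compound 2 and compound 3 differ by a number 18.2 percentage points higher from compound 2 to compound 3 (beyond the scatter).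

Compound 4 `O=C(Nc1cccc(Cl)c1)c1c(O)c2cccnc2n(-c2ccccc2)c1=O` is not yet measured. It differs from compound 3 by chloro in place of methoxy on an aromatic carbon. This is the same kind of change as from compound 1 to compound 2, though there the group sat para to a large group and here meta to a large group. A step of a number 3.3 percentage points higher from compound 3 to compound 4 (within the scatter) is expected from compound 3 to compound 4, because a number 4.4 percentage points higher from compound 1 to compound 2 (within the scatter) was small. For compound 4 the estimated value is 24%, expected between 6% and 42%.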

Compound 4, a percentage reported as inhibition, in the whole organism at one dose (the size of the read-out at that dose, not a potency): 13.4%
Compound 4: the middle estimate sits 10.6 percentage points above what was measured, within the range that was stated.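

In this assay, chloro in place of methoxy gave a number 7.3 percentage points lower from compound 3 to compound 4 (within the scatter), and the two cores do not part on this change: the same change on two cores in this assay, a number 4.4 percentage points higher (within the scatter) from compound 1 to compound 2 and a number 7.3 percentage points lower (within the scatter) from compound 3 to compound 4, 11.7 percentage points apart, within the scatter of two such steps. The swap therefore carries across these two cores as a step too small to read, which does not prove it has no effect and says nothing about other cores. The 3-chlorophenyl group of compound 4 does stand apart from the 4-substituted rings, with a number 10.9 percentage points higher from compound 2 to compound 4 (beyond the scatter) and a number 15.3 percentage points higher from compound 1 to compound 4 (beyond the scatter).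

Still open, as far as these compounds go, is how an amine, a carboxylic acid or a longer chain in that ring position would compare with methoxy and chloro. Also open, from the compounds shown here alone, is whether these small differences would hold at other doses.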